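This account rests on a few compounds, and the source may have more. Where it says the series, first, only, none or still open, it means among the compounds named here.

Three analogues of the shared core carry different aryl groups on the amine nitrogen: compound 1 `O=C1C=C(Nc2ccc(I)cc2)C(=O)c2c1nc1n2[C@H]2OC[C@@H](O)[C@H]2OC1`, compound 2 `Cc1ccc(NC2=CC(=O)c3c(nc4n3[C@H]3OC[C@@H](O)[C@H]3OC4)C2=O)cc1C` and compound 3 `COc1cccc(NC2=CC(=O)c3nc4n(c3C2=O)[C@H]2OC[C@@H](O)[C@H]2OC4)c1`. In a functional assay on MGC-803 cells (Homo sapiens) for inhibition, read by sulforhodamine B assay (a higher number here means a weaker inhibitor, a lower number a stronger inhibitor), compound 1 gives 1400 nM, compound 2 gives 1050 nM and compound 3 gives 1780 nM. Compound 2 shows the lowest number of the three, yet its gaps to compound 1 and to compound 3 both sit within the scatter. Compound 4 `Cc1ccc(NC2=CC(=O)c3c(nc4n3[C@H]3OC[C@@H](O)[C@H]3OC4)C2=O)cc1` is not yet measured; it differs from compound 2 by hydrogen in place of methyl on an aromatic carbon. Within the data shown here, the only measured step, a 1.3-fold higher number from compound 1 to compound 3 (0.10 log units; within the scatter), exchanges whole aryl groups, and no step removes a single methyl. The step from compound 2 to compound 4 is therefore expected to be a 1.2-fold higher number from compound 2 to compound 4 (0.09 log units; within the scatter), within the scatter. Compound 4 is estimated in this assay at 1300 nM, range 700 nM to 2500 nM.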

Compound 4, half-maximal inhibitory concentration: 1550 nM
The estimate for compound 4 lay 1.2-fold (0.08 log units) below the measured number; measured number inside the range.
By their numbers in this assay, from the lowest: compounds 2, 1, 4 and 3 (each within the scatter of the next).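

In this assay, going from 3,4-dimethylphenyl to 4-methylphenyl gives a 1.5-fold higher number from compound 2 to compound 4 (0.17 log units; within the scatter). Among these compounds, this is the only step that changes a single methyl, and at this aromatic carbon, ortho to a methyl group and meta to a large group, the data do not separate hydrogen from methyl. No measured evidence bears on this result.

On these data alone, whether an amine or a carboxylic acid on this carbon would give a step beyond the scatter remains open. So does the effect of removing the remaining methyl to leave an unsubstituted phenyl.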